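A few compounds are considered here, and "the series" means these few. Any claim that something is new, unique, unknown or untested is made for them only; others in the source may bear on it.

Measured so far in a functional assay on K562 cells (Homo sapiens) for cytotoxicity, read by MTT assay, with a stated time of 24 h; a lower number here means a stronger inhibitor, a higher number a weaker inhibitor

compound 1 `COc1cc(/C=C2\CN(C)C/C(=C\c3ccccc3F)C2=O)cc(OC)c1` gives 6320 nM
compound 2 `CN1C/C(=C\c2ccc(C(C)(C)C)cc2)C(=O)/C(=C/c2ccccc2F)C1` gives 18200 nM
compound 3 `CN1C/C(=C\c2cccc([N+](=O)[O-])c2)C(=O)/C(=C/c2ccccc2F)C1` gives 3890 nM

Compound 1 lies within the scatter of compound 3, so these two cannot be told apart. Compound 2 gives the highest of the three numbers, beyond the scatter from compound 1.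

The unmeasured compound 4 `COc1cc(/C=C2\CN(C)C/C(=C\c3ccc(Cl)cc3Cl)C2=O)cc(OC)c1` has 2,4-dichlorophenyl in place of the 2-fluorophenyl of compound 1, on a double-bonded chain carbon bound to a double-bonded ring carbon (2,4-dichlorophenyl in place of 2-fluorophenyl on a double-bonded chain carbon bound to a double-bonded ring carbon). Within the data shown here, all three measured compounds carry 2-fluorophenyl, so no measured pair shows what replacing it does. Starting from compound 1 at 6320 nM as the reference, no step beyond the scatter is expected in this assay, and these data support no firm direction. The estimated step is small, a 1.3-fold lower number from compound 1 to compound 4 (0.10 log units; within the scatter) and is expected to stay within the scatter. For compound 4 the expected value is 5000 nM with an estimated range from 2000 nM to 13000 nM as a working estimate.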

Compound 4, half-maximal inhibitory concentration: 11900 nM
Estimate against measurement, compound 4: 2.4-fold (0.38 log units) below; the measured number falls inside the stated range.
By their numbers in this assay, from the lowest: compounds 3, 1, 4 and 2 (each within the scatter of the next, the first and the last beyond it).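

In this assay compound 4 is the only compound shown that departs from 2-fluorophenyl on a double-bonded chain carbon bound to a double-bonded ring carbon, and the change to 2,4-dichlorophenyl gives a 1.9-fold higher number from compound 1 to compound 4 (0.27 log units; within the scatter). Compounds 1 and 4 therefore cannot be told apart, so at this position, with the rest of compound 1 held fixed, this exchange of one halogenated phenyl for another produces no readable change in the number. No measurement here offers an explanation for this result.

From the compounds shown here alone, it remains open whether a phenyl carrying an amine or a carboxylic acid, or a saturated cyclohexyl ring, would move the number beyond the scatter at this position. Whether 2,4-dichlorophenyl behaves the same way alongside the other groups in compounds 2 and 3 is also unresolved.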